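A Shorter Branched Chain on Two Related Cores

The source may hold more compounds than are shown below. What is called first, only, known or untested is meant among the compounds shown, and "the series" means these compounds.

Compound 1 `CCCCCCCCNc1ccc([N+](=O)[O-])cc1S(N)(=O)=O` and compound 2 `CC(C)(C)CCNc1ccc([N+](=O)[O-])cc1S(N)(=O)=O` share one core, while compound 3 `CCCCCCCCNc1ccc(C(=O)O)cc1S(=O)(=O)NC` is built on another; the difference between the two cores is not broken down here. In an assay on HEK293 cells for inhibition of solute carrier family 12 member 2 (Homo sapiens), read by fluorescence, with a stated time of 30 min, tested at 100 uM (on this read-out lower numbers stand for a weaker effect and higher numbers for a stronger effect at the one concentration tested), compound 1 gives 5.8% and compound 2 gives 14.5%. The change between them is tert-butyl in place of hexyl on a saturated chain carbon, two bonds along the chain from a nitrogen on an aromatic ring, and it made a step of a number 8.7 percentage points higher from compound 1 to compound 2 (within the scatter). In this assay compound 3 gives 20.1%, which is the highest of the three numbers, beyond the scatter from compound 1 but within it of compound 2. Compound 4 `CNS(=O)(=O)c1cc(C(=O)O)ccc1NCCC(C)(C)C` has not yet been measured; it differs from compound 3 by tert-butyl in place of hexyl on a saturated chain carbon, two bonds along the chain from a nitrogen on an aromatic ring, the same kind of change at a place described in the same words. Because the step of a number 8.7 percentage points higher from compound 1 to compound 2 (within the scatter) stayed within the scatter, the step to compound 4 is expected to be small, about a number 4.9 percentage points higher from compound 3 to compound 4 (within the scatter). The value expected for compound 4 in this assay is 25%, most likely falling between 10% and 40%.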

Compound 4, a percentage reported as inhibition, at one concentration (the size of the read-out at that concentration, not a potency): 2.6%
The estimate for compound 4 lay 22.4 percentage points above the measured number; the measured number lies below the stated range.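

On the core of compound 3, putting tert-butyl in place of hexyl in this assay made a step of a number 17.5 percentage points lower from compound 3 to compound 4 (beyond the scatter), so a step read on one core could not be carried over to the other. The same change gave clearly different steps on the two cores: the same change on two cores in this assay, a number 8.7 percentage points higher (within the scatter) from compound 1 to compound 2 and a number 17.5 percentage points lower (beyond the scatter) from compound 3 to compound 4, 26.2 percentage points apart, beyond the scatter of two such steps This does not show which part of the cores sets the steps apart, and a single pair on each core cannot show how any other change would carry over, while a reading at one concentration is not a potency.

The compounds shown leave open how a pentyl chain or a cyclohexyl group at this place would read on either core. They also leave open whether a core with an amine in place of the carboxylic acid would follow the step seen on the core of compound 1 or the one seen on the core of compound 3.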